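The compounds below may be only part of what the source reports. "The series", "measured", "known", "first", "only" and "open" are said of these compounds alone.

In a functional assay on A549 cells (Homo sapiens) for inhibition, read by MTT assay, with a stated time of 72 h (on this read-out lower numbers stand for stronger inhibition and higher numbers for weaker inhibition), compound 3 (`C=C(Cl)C(=O)Nc1cc(Nc2nc3c(c(-c4cn(C)c5ccc(F)cc45)n2)CS(=O)(=O)CC3)c(OC)cc1N(C)CCN(C)C`) stands at 3180 nM within the scatter of compound 2 (`C=CC(=O)Nc1cc(Nc2nc3c(c(-c4cn(C)c5ccc(F)cc45)n2)CS(=O)(=O)CC3)c(OC)cc1N(C)CCN(C)C`) at 4640 nM and clearly higher than compound 1 (`COc1cc(N(C)CCN(C)C)c(NC(=O)C=C(C)C)cc1Nc1nc2c(c(-c3cn(C)c4ccccc34)n1)CS(=O)(=O)CC2`) at 787 nM on these numbers.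

Compound 4 (`COc1cc(N(C)CCN(C)C)c(NC(=O)C=C(C)C)cc1Nc1nc2c(c(-c3cn(C)c4ccc(F)cc34)n1)CS(=O)(=O)CC2`) differs from compound 3 as follows: 2-methylprop-1-en-1-yl in place of 1-chloroethenyl on a carbonyl carbon with 2-methylprop-1-en-1-yl in place of 1-chloroethenyl on a carbonyl carbon.

Among the measured compounds shown here, the one measured step on this chain is a 1.5-fold lower number from compound 2 to compound 3 (0.16 log units; within the scatter) and it gives no sign of a large effect there. For the measured compounds named here, compound 1 at 787 nM already carries the 2-methylprop-1-en-1-yl group, but its core differs from that of compound 4, and no measured pair isolates the group on the shared core of compound 3.

A modest shift toward a lower number is therefore expected in this assay with the size staying within the scatter. The estimated change is a 1.6-fold lower number from compound 3 to compound 4 (0.20 log units; within the scatter) with no larger move firmly expected.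

For compound 4 the estimated value is 2000 nM with an expected range of 800 nM to 4500 nM in this read-out.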

Compound 4, half-maximal inhibitory concentration: 2140 nM
The estimate for compound 4 lay 1.1-fold (0.03 log units) below the measured number; the measured number falls inside the stated range.
By their numbers in this assay, from the lowest: compound 1; then compounds 4, 3 and 2 (each within the scatter of the next, the first and the last beyond it).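

In this assay, among the compounds shown here, the change to 2-methylprop-1-en-1-yl on the carbonyl carbon gives a 1.5-fold lower number from compound 3 to compound 4 (0.17 log units; within the scatter), so this group and 1-chloroethenyl are not separated on the shared core, whereas the comparison with vinyl gives a 2.2-fold lower number from compound 2 to compound 4 (0.34 log units; beyond the scatter) and is the first modest change at this position that lies beyond the scatter. With 2-methylprop-1-en-1-yl held constant, fluoro in place of hydrogen on an aromatic carbon gives a 2.7-fold higher number from compound 1 to compound 4 (0.43 log units; beyond the scatter), a first modest read of that change, toward weaker inhibition. No measurement at hand accounts for either modest step.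

From the compounds shown here alone, whether the fluoro step carries over when vinyl or 1-chloroethenyl sits on the carbonyl carbon remains open. Also open, going by these compounds, is how a longer chain or a chain bearing an amine at this position would read in this assay.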